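The compounds below may be only part of what the source reports. "The series", "measured", "known", "first", "only" and "open" are said of these compounds alone.

The measured compounds so far:

compound 1, `COc1ccc(-c2cncc(C(=O)N(C)C)c2)cc1S(=O)(=O)Nc1cccc(NCCNC(=O)c2cccc(C)c2)c1`, with 619 nM
compound 2, `COc1ccc(-c2csc(C(=O)N(C)C)n2)cc1S(=O)(=O)Nc1cccc(NCCNC(=O)c2cccc(C)c2)c1`, with 354 nM

Both were tested in a functional assay on CHO-RD-HGA16 cells for agonist activity at Orexin receptor type 2 (Homo sapiens), read by fluorescence and calcium flux, with a stated time of 30 min; on this read-out higher numbers stand for an effect only at larger amounts of compound and lower numbers for an effect already at smaller amounts. Going by the values given here, compound 2 holds the lower of the two numbers, but the only measured step, a 1.7-fold lower number from compound 1 to compound 2 (0.24 log units; within the scatter), lies within the scatter, so the two compounds cannot be ranked against each other.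

Compound 3, `COc1ccc(/C=C/C(=O)N(C)C)cc1S(=O)(=O)Nc1cccc(NCCNC(=O)c2cccc(C)c2)c1`, differs from compound 2 by one change: 2-(dimethylcarbamoyl)ethenyl in place of 2-(dimethylcarbamoyl)-1,3-thiazol-4-yl on an aromatic carbon. The step from compound 1 to compound 2 is the only one that bears on this change, and it exchanged one aromatic ring carrying the dimethylcarbamoyl group for another without moving beyond the scatter. The change to compound 3 removes the ring altogether, so that step gives only weak guidance. The step of a 1.8-fold higher number from compound 2 to compound 3 (0.26 log units; within the scatter) is expected to be a modest move toward higher numbers, with a wide range. Compound 3 is estimated at 650 nM, between 150 nM and 2800 nM.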

Compound 3, half-maximal effective concentration: > 10000 nM
Compound 3 was reported as a limit (the forecaster's own chance of this, stated with the estimate: 10%); middle value at least 15-fold (1.18 log units) from the limit.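

Compound 3 is reported only as a limit of the assay: the limit of > 10000 nM in this assay, at which 1 of the 3 values shown sits.

Compound 1 and compound 2 both carry the dimethylcarbamoyl group on an aromatic ring and could not be ranked, whereas replacing either ring with the open 2-(dimethylcarbamoyl)ethenyl group gives an at least 28-fold higher number from compound 2 to compound 3 (1.45 log units; beyond the scatter) and an at least 16-fold higher number from compound 1 to compound 3 (1.20 log units; beyond the scatter), both beyond the scatter. Thus, at this position para to a methoxy group, the exchange of one aromatic ring for another showed no measurable difference, while the loss of the ring, which the earlier pair could not test, brings a large step.

The compounds shown do not separate the loss of the ring from the change to the ethenyl link. From the compounds shown here alone, it also remains open whether the thiazole ring would keep its number with a carboxylic acid or a nitrile in place of the dimethylcarbamoyl group.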